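The source may hold more compounds than are shown below. What is called first, only, known or untested is meant among the compounds shown, and "the series" means these compounds.

Working notes on the series.

Compound 1 `CCC(C(=O)N1CCN(c2cccc(OC)c2)CC1)N1C(=O)CCC1=O` gives 0% in a functional assay on the whole organism (strain Swiss) with Mus musculus as the target, in the maximal electroshock model, with a stated time of 2 h, at a dose of 300 mg/kg by the intraperitoneal route; a higher number here means a stronger effect of the compound at the dose given, a lower number a weaker effect. Compound 2 `CCC(C(=O)N1CCN(c2cccc(F)c2)CC1)N1C(=O)CCC1=O` differs from it by fluoro in place of methoxy on an aromatic carbon, and in this assay compound 2 gives 0%. The step of no change at the digits printed from compound 1 to compound 2 (within the scatter) therefore shows nothing beyond the scatter: exchanging the group on the aromatic carbon left the read-out where it was. Compound 2 thus stands level with compound 1, both without any detectable effect at the dose tested.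

Compound 3 `CCC(C(=O)N1CCN(c2cccc(C(F)(F)F)c2)CC1)N1C(=O)CCC1=O` is not yet measured. Its change from compound 2 is trifluoromethyl in place of fluoro on an aromatic carbon. Going by the values given here, the only measured step that bears on this position is no change at the digits printed from compound 1 to compound 2 (within the scatter), which was flat, so there is no evidence that the group on this aromatic carbon moves the read-out. Two flat compounds give no basis for expecting a rise, and the read-out cannot fall further. The expected step of a number 5 percentage points higher from compound 2 to compound 3 (within the scatter) is accordingly none beyond the scatter. For compound 3 the estimate in this assay is 5%, with a range from 0% to 30%, the upper end allowing for a small effect not seen so far.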

Compound 3, a percentage reported as activity, at one dose (the size of the read-out at that dose, not a potency): 50%
Compound 3: middle estimate off by 45 percentage points, on the low side, and the stated range ends below it.
By their numbers in this assay, from the lowest: compounds 1 and 2 (each within the scatter of the next); then compound 3.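

In this assay the group on this aromatic carbon does move the read-out: trifluoromethyl in place of fluoro gives a number 50 percentage points higher from compound 2 to compound 3 (beyond the scatter) and trifluoromethyl in place of methoxy gives a number 50 percentage points higher from compound 1 to compound 3 (beyond the scatter) on the shared core. The flat step no change at the digits printed from compound 1 to compound 2 (within the scatter) therefore holds for the pair fluoro and methoxy only and does not describe the position as a whole, and compound 3 stands alone above the other two compounds. The change itself enlarges the group from one heavy atom to four and adds no hydrogen-bond donor, hydrogen-bond acceptor, ring or net charge, but no measurement at hand says why the read-out rises.

The three compounds leave open whether the rise is particular to trifluoromethyl or also appears with other groups on this aromatic carbon, such as chlorine, methyl or a nitrile. They also leave open how compound 3 behaves at other doses and times, since a read-out at one dose gives the size of the effect there and not a potency.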